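The compounds below may be only part of what the source reports. "The series", "measured", "known", "first", "only" and "open" are said of these compounds alone.

Measured compounds:
- compound 1, `Cc1cc(C)nc(SCc2cc(=O)c3cc(Cl)ccc3o2)n1`: in a functional assay on SW480 cells (Homo sapiens) for cytotoxicity, read by MTT assay, with a stated time of 72 h (a lower number here means a stronger inhibitor, a higher number a weaker inhibitor), compound 1 gives only a limit, > 25000 nM
- compound 2, `Cc1nnc(SCc2coc3ccc(Cl)cc3c2=O)o1`: in this assay compound 2 gives 3500 nM

For the measured compounds named here, compound 2 holds the only number in this assay so far; the other value shown is a limit, namely (the limit of > 25000 nM in this assay, at which 1 of the 2 values shown sits). Going by the values given here, no step between measured compounds is available, as compound 1 and compound 2 differ in more than one place, and what their two values show is that compound 2 gives a number while compound 1 does not.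

Compound 3, `Cc1nnc(SCc2coc3ccc(Cl)cc3c2=O)s1`, is next. It differs from compound 2 by 5-methyl-1,3,4-thiadiazol-2-yl in place of 5-methyl-1,3,4-oxadiazol-2-yl on a sulfur. No comparable swap has been measured in this series, so the expected step in this assay is small, in either direction, and most likely within the scatter; a mild gain is the lean. The estimate for compound 3 in this assay is 2500 nM, between 800 nM and 8000 nM, which corresponds to an expected step of a 1.4-fold lower number from compound 2 to compound 3 (0.15 log units; within the scatter).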

Compound 3, half-maximal inhibitory concentration: 3200 nM
Estimate against measurement, compound 3: 1.3-fold (0.11 log units) below; low and high end bracket the measured number.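

For the compounds shown here, the swap of 5-methyl-1,3,4-oxadiazol-2-yl for 5-methyl-1,3,4-thiadiazol-2-yl on a sulfur gives the first readable step: in this assay, the change gives a 1.1-fold lower number from compound 2 to compound 3 (0.04 log units; within the scatter), so the exchange of the ring oxygen for a ring sulfur leaves no readable difference. At this position, on a sulfur whose other neighbours are a saturated chain carbon, the two five-membered aromatic rings can therefore be treated as interchangeable in this read-out, though only for this one pair on this shared core. No measured property of either group bears on this result, and the near-identical values offer nothing to explain.

Compound 1 gives only a limit, > 25000 nM, and its step to the other compounds cannot be read, as it differs from them in more than one place. Still open, as far as these compounds go, is whether an amine, a carboxylic acid or a longer chain in place of the methyl on the 5-methyl-1,3,4-thiadiazol-2-yl group would move the number in this assay beyond the scatter.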